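A few compounds are considered here, and "the series" means these few. Any claim that something is new, unique, unknown or untested is made for them only; others in the source may bear on it.

Measured so far in a functional assay on Huh-7 cells (Homo sapiens) for inhibition, read by MTT assay, with a stated time of 48 h; a higher number here means a weaker inhibitor, a lower number a stronger inhibitor: compound 1 `COc1ccc2c(=O)c(/C=C/C(=O)Nc3cccc(Cl)c3)coc2c1` gives > 100000 nM, which is a limit of the assay rather than a number. Compound 2 `Cc1ccccc1NC(=O)/C=C/c1coc2cc(O)ccc2c1=O` gives 11100 nM. Compound 3 `COc1ccc2c(=O)c(/C=C/C(=O)NCc3ccccc3)coc2c1` gives 13600 nM.

Compound 3 holds the higher of the two real numbers, but its gap to compound 2 is within the usual scatter, and the third value is only a limit. Compound 4 `COc1ccc2c(=O)c(/C=C/C(=O)Nc3ccccc3C)coc2c1` differs from compound 3 in one place: 2-methylphenyl in place of benzyl on an amide-type nitrogen. Going by the values given here, the only measured step at this amide nitrogen, an at least 7.3-fold lower number from compound 1 to compound 3 (0.86 log units; beyond the scatter), ran the other way, with an aromatic ring directly on the nitrogen giving the higher number, though that step rests on a limit (the limit of > 100000 nM in this assay, at which 1 of the 3 values shown sits). Compound 2 also carries 2-methylphenyl on the nitrogen and sits within the scatter of compound 3. Compound 4 is therefore expected to give a somewhat higher number, a 2.2-fold higher number from compound 3 to compound 4 (0.34 log units; beyond the scatter), with an estimate of 30000 nM in this assay, between 8000 nM and 150000 nM.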

Compound 4, half-maximal inhibitory concentration: 26900 nM
For compound 4 the middle estimate is 1.1-fold (0.05 log units) above the measured one; the range from low to high includes it.
By their numbers in this assay, from the lowest: compounds 2, 3 and 4 (each within the scatter of the next, the first and the last beyond it). At a limit, above all of these: compound 1.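

The step of a 2.0-fold higher number from compound 3 to compound 4 (0.30 log units; within the scatter) shows that in this assay benzyl and 2-methylphenyl on the amide-type nitrogen cannot be told apart. With 2-methylphenyl held in place, methyl in place of hydrogen on the oxygen on the aromatic ring gives a 2.4-fold higher number from compound 2 to compound 4 (0.38 log units; beyond the scatter) and is a modest change. Compound 1 stands at a limit and not at a number, so an at least 3.7-fold lower number from compound 1 to compound 4 (0.57 log units; beyond the scatter) is only a bound on how far 3-chlorophenyl and 2-methylphenyl differ: the limit of > 100000 nM in this assay, at which 1 of the 4 values shown sits.

From the compounds shown here alone, how an amine or a carboxylic acid on the ring, or a longer chain in place of benzyl, would read in this assay stays open.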